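Urea series: swapping the substituent at one aromatic carbon

A few compounds are considered here, and "the series" means these few. Any claim that something is new, unique, unknown or untested is made for them only; others in the source may bear on it.

Working notes on the series, read in a functional assay on CRL2813 cells (Homo sapiens) for cytotoxicity, read by sulforhodamine B assay, with a stated time of 5 days; on this read-out lower numbers stand for stronger inhibition and higher numbers for weaker inhibition.

Measured so far:
- compound 1, `O=C(Nc1ccccc1I)N[C@H]1CC[C@H](Oc2ccc(F)cc2)CC1`: in this assay compound 1 is reported only as the limit > 20000 nM.
- compound 2, `O=C(Nc1ccccc1Br)N[C@H]1CC[C@H](Oc2ccc(F)cc2)CC1`: in this assay compound 2 gives 7700 nM.
- compound 3, `CSc1ccccc1NC(=O)N[C@H]1CC[C@H](Oc2ccc(F)cc2)CC1`: in this assay compound 3 is reported only as the limit > 20000 nM.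

Compound 3 therefore stands at the assay limit, not at a number; (the limit of > 20000 nM in this assay, at which 2 of the 3 values shown sit). Among the three values it is one of two at that limit, so compound 3 cannot be ordered against compound 1, and the step that the two limits leave unreadable from compound 1 to compound 3 stays unreadable. Only compound 2 carries a readable number.

Compound 4, `O=C(Nc1ccccc1C(F)(F)F)N[C@H]1CC[C@H](Oc2ccc(F)cc2)CC1`, is not yet measured. The change from compound 3 is trifluoromethyl in place of methylsulfanyl on an aromatic carbon. For the measured compounds named here, no measured step introduces trifluoromethyl, so none bears on it directly. Going by the values given here, the measured steps at the same carbon, an at least 2.5-fold lower number from compound 1 to compound 2 (0.41 log units; beyond the scatter) and an at least 2.5-fold higher number from compound 2 to compound 3 (0.41 log units; beyond the scatter), show only that the bromo compound alone yields a number below the limit. Because compound 3 sits at the limit, the step to compound 4 becomes readable only if compound 4 falls below it.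

Compound 4 is expected to remain weak, estimated at 15000 nM with a range of 5000 nM to 40000 nM. This estimate means an at least 1.3-fold lower number from compound 3 to compound 4 (0.12 log units; that floor lies within the scatter), with a fair chance that only a limit is reported.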

Compound 4, half-maximal inhibitory concentration: > 20000 nM
Compound 4: no number, only a limit; the forecaster's own chance of this, stated with the estimate: 50%; middle value at least 1.3-fold (0.12 log units) from the limit.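

Trifluoromethyl at this aromatic carbon adds a third group that gives no number. In this assay compound 4 is reported only as the limit > 20000 nM. Bromo in compound 2 therefore remains the only group here with a readable value, and replacing it with trifluoromethyl gives an at least 2.5-fold higher number from compound 2 to compound 4 (0.41 log units; beyond the scatter); the steps from compound 1 and compound 3 to compound 4 cannot be read, and the series now stands at: the limit of > 20000 nM in this assay, at which 3 of the 4 values shown sit.

The order among iodo, methylsulfanyl and trifluoromethyl stays unresolved, as does how far each lies from compound 2. Going by these compounds, whether chloro, methoxy, a nitrile or an amine at this carbon would also give a readable value, or whether bromo stands alone, remains open.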